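Working notes: from compound 2 to compound 4

This account rests on a few compounds, and the source may have more. Where it says the series, first, only, none or still open, it means among the compounds named here.

Measured so far in a functional assay on SGC-7901 cells (Homo sapiens) for inhibition; a lower number here means a stronger inhibitor, a higher number a weaker inhibitor:
compound 1 `CC(C)=CCC/C(C)=C/C[C@]12C[C@@H](CC=C(C)C)C(C)(C)[C@](CC=C(C)C)(C(=O)C(C(=O)c3ccc(O)c(O)c3)=C1O)C2=O`: 5.48 ug/mL
compound 2 `CC(C)=CCC/C(C)=C/C[C@@H]1C[C@]2(CC=C(C)C)C(=O)[C@@](CC=C(C)C)(C(=O)C(C(=O)c3ccc(O)c(O)c3)=C2O)C1(C)C`: > 20 ug/mL, a limit of the assay
compound 3 `CC(C)=CCC/C(C)=C/C[C@]12C[C@@H](CC=C(C)C)C(C)(C)[C@](C/C=C(\C)CCC=C(C)C)(C(=O)C(C(=O)c3ccc(O)c(O)c3)=C1O)C2=O`: > 20 ug/mL, a limit of the assay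

Compound 2 stands at the limit: in this assay compound 2 gives only > 20 ug/mL, which is a limit and not a number. Of the three values shown, two sit at that limit (the limit of > 20 ug/mL in this assay, at which 2 of the 3 values shown sit). Going by the values given here, compound 1 is the only compound of the three with a measured number.

Compound 4 `CC(C)=CCC/C(C)=C/C[C@@H]1C[C@]2(C/C=C(\C)CCC=C(C)C)C(=O)[C@@](CC=C(C)C)(C(=O)C(C(=O)c3ccc(O)c(O)c3)=C2O)C1(C)C` differs from compound 2 in one place: 3-methylbut-2-en-1-yl in place of hydrogen on a saturated chain carbon bound to a double-bonded chain carbon. One measured step is of the same kind, an at least 3.6-fold higher number from compound 1 to compound 3 (0.56 log units; beyond the scatter), where the number went from a measured value up to the limit. Among the compounds with values here, that step is the only guide here. Since compound 2 already sits at the limit, the same change is expected to leave compound 4 at or beyond it, with no step beyond the scatter that a limit could reveal; the expected step is a step that the limit leaves unreadable from compound 2 to compound 4. The estimate for compound 4 in this assay is 30 ug/mL, between 15 ug/mL and 80 ug/mL, and most likely reported again only as a limit.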

Compound 4, half-maximal inhibitory concentration: 4.05 ug/mL
Beside the measured number, compound 4's estimate is 7.4-fold (0.87 log units) above it, and the stated range ends above it.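

In this assay compound 2 stands only at a limit of the assay, > 20 ug/mL. At this place, 3-methylbut-2-en-1-yl in place of hydrogen on a saturated chain carbon bound to a double-bonded chain carbon gives an at least 4.9-fold lower number from compound 2 to compound 4 (0.69 log units; beyond the scatter), and the direction of the change therefore depends on the core that carries it: the same change on two cores in this assay, an at least 3.6-fold higher number (0.56 log units; beyond the scatter) from compound 1 to compound 3 and an at least 4.9-fold lower number (0.69 log units; beyond the scatter) from compound 2 to compound 4, at least 18-fold (1.25 log units) apart, beyond the scatter of two such steps. The two compounds with measured numbers are level, with a 1.4-fold lower number from compound 1 to compound 4 (0.13 log units; within the scatter).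

Only the 3-methylbut-2-en-1-yl and 3,7-dimethylocta-2,6-dien-1-yl chains appear at this place, leaving open how a methyl group, a longer chain, or a chain ending in an amine or a carboxylic acid would read on either core. Going by these compounds, the full size of each step with one end at a limit also stays open: the limit of > 20 ug/mL in this assay, at which 2 of the 4 values shown sit.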